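The compounds below may be only part of what the source reports. "The series", "measured", "known", "first", "only" and "open" are said of these compounds alone.

Compound 2 `CC(C)CCNc1ncc(-c2cccc(Cl)c2)c(-c2ccccc2)n1` carries an isopentyl group on a nitrogen on an aromatic ring. Among the compounds with values here, in an assay on CHO cells for displacement of a labelled ligand from adenosine receptor A1 (Homo sapiens), read by scintillation counting, with a stated time of 1 h, tested at 1 uM (on this read-out lower numbers stand for less inhibition and higher numbers for more inhibition at the one concentration tested (going by the name of the read-out)), compound 2 gives 39%, the only plain number among the two values shown. Compound 1 `Clc1cccc(-c2cnc(NC3CCCC3)nc2-c2ccccc2)c1` carries cyclopentyl in that same place. In this assay compound 1 reaches > 80%, which is a limit of the assay rather than a number (the limit of > 80% in this assay, at which 1 of the 2 values shown sits). Within the data shown here, the one measured step runs a number at least 41 percentage points lower from compound 1 to compound 2 (beyond the scatter). Compound 3 `Clc1cccc(-c2cnc(NCCCc3ccccc3)nc2-c2ccccc2)c1` differs from compound 2 by benzyl in place of isopropyl on a saturated chain carbon, two bonds along the chain from a nitrogen on an aromatic ring. Among the measured compounds shown here, no measured step covers this change directly; the step from compound 1 to compound 2 shows only that swapping the group on that nitrogen can shift the read-out a long way, without telling which way a longer chain ending in an aromatic ring will go. Compound 3 is therefore expected to land between the two measured values, a step of a number 16 percentage points higher from compound 2 to compound 3 (beyond the scatter). Compound 3 is estimated at 55%, between 25% and 85%.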

Compound 3, a percentage reported as inhibition, at one concentration (the size of the read-out at that concentration, not a potency): 33%
Compound 3: the middle estimate sits 22 percentage points above what was measured; the range from low to high includes it.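

Putting benzyl in place of isopropyl on a saturated chain carbon, two bonds along the chain from a nitrogen on an aromatic ring, gives a number 6 percentage points lower from compound 2 to compound 3 (within the scatter), so in this assay the larger group with its aromatic ring cannot be told apart from the smaller one. Replacing the ring on that nitrogen with a chain that carries an aromatic ring gives a result like that of the isopentyl chain, as 3-phenylpropyl in place of cyclopentyl on a nitrogen on an aromatic ring gives a number at least 47 percentage points lower from compound 1 to compound 3 (beyond the scatter). The value of compound 1 is a limit and not a plain number: the limit of > 80% in this assay, at which 1 of the 3 values shown sits.

The compounds shown leave open whether cyclohexyl, a ring of another size, on that nitrogen would match compound 1. They also leave open what a hydroxyl group or an amine on the chain would do to the read-out.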